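Methyl on the hydroxy oxygen of compound 1

The compounds below may be only part of what the source reports. "The series", "measured", "known", "first", "only" and "open" are said of these compounds alone.

In a functional assay on HT-29 cells (Homo sapiens) for inhibition, read by MTT assay, with a stated time of 2 days (on this read-out lower numbers stand for stronger inhibition and higher numbers for weaker inhibition), compound 1 (`Nc1ccc(/C=C/c2cccc(O)c2)cc1`) gives 42 ug/mL and compound 2 (`COc1ccc(/C=C/c2cccc(O)c2)cc1`) gives 22 ug/mL. Within the data shown here, these are the only two numbers so far, and they lie within the scatter of each other. Compound 3 (`COc1cccc(/C=C/c2ccc(N)cc2)c1`) differs from compound 1 by methyl in place of hydrogen on an oxygen on an aromatic ring, hydroxy to methoxy. Among the measured compounds shown here, the one measured step, a 1.9-fold lower number from compound 1 to compound 2 (0.28 log units; within the scatter), is a different change, methoxy in place of amino on an aromatic carbon, so it bears only indirectly. No step beyond the scatter is expected in this assay. The estimate for compound 3 is 32 ug/mL, with an expected range of 14 ug/mL to 70 ug/mL. This estimate means a 1.3-fold lower number from compound 1 to compound 3 (0.12 log units; within the scatter).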

Compound 3, half-maximal inhibitory concentration: 16.1 ug/mL
Beside the measured number, compound 3's estimate is 2.0-fold (0.30 log units) above it, and the stated range covers the measured number.
By their numbers in this assay, from the lowest: compounds 3, 2 and 1 (each within the scatter of the next, the first and the last beyond it).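

Methyl on the oxygen gives the first step in this series that lies beyond the scatter: in this assay, hydroxy to methoxy brings a 2.6-fold lower number from compound 1 to compound 3 (0.42 log units; beyond the scatter), modest in size. The hydroxy hydrogen at this place can therefore be replaced by methyl with no loss on this read-out, with the amino group of compound 1 kept. Nothing measured here bears on the reason for this step.

As far as these compounds go, whether an ethoxy group or a longer chain on this oxygen extends the step remains open. Also open, from the compounds shown here alone, is whether the same methyl gives a similar step on compound 2, which carries methoxy in place of amino.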